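Shifting the chlorine on the benzyl group

This account rests on a few compounds, and the source may have more. Where it says the series, first, only, none or still open, it means among the compounds named here.

Compound 1 `FC(F)(F)c1ccc(CO/N=C/c2c(-c3ccc4ccccc4c3)nc3occn23)cc1`: 470 nM
Compound 2 `Clc1ccccc1CO/N=C/c1c(-c2ccc3ccccc3c2)nc2occn12`: 1100 nM

In an assay on HepG2 cells for agonist activity at nuclear receptor subfamily 1 group I member 3 (Homo sapiens), read by a luciferase reporter, with a stated time of 23 h (on this read-out lower numbers stand for an effect already at smaller amounts and higher numbers for an effect only at larger amounts of compound), compound 2 gives the highest of the two numbers measured, with compound 1 nearest at a 2.3-fold higher number from compound 1 to compound 2 (0.37 log units; beyond the scatter). Compound 3 `Clc1ccc(CO/N=C/c2c(-c3ccc4ccccc4c3)nc3occn23)cc1` differs from compound 2 by 4-chlorophenyl in place of 2-chlorophenyl on a saturated chain carbon bound to an oxygen on an unsaturated carbon. Within the data shown here, no measured step changes only the ring position of a chlorine; the one step at hand, from compound 1 to compound 2, combined a change of substituent with a change of its place. Compound 3 shares the 4-substitution of compound 1, so a modest move toward lower numbers is expected, a 1.8-fold lower number from compound 2 to compound 3 (0.26 log units; within the scatter). Compound 3 is therefore estimated at 600 nM, in a range of 250 nM to 1500 nM.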

Compound 3, half-maximal effective concentration: 990 nM
Compound 3: the middle estimate sits 1.7-fold (0.22 log units) below what was measured; the measured number falls inside the stated range.
By their numbers in this assay, from the lowest: compound 1; then compounds 3 and 2 (each within the scatter of the next).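

In this assay, moving the chlorine gives a 1.1-fold lower number from compound 2 to compound 3 (0.05 log units; within the scatter) and so does not separate the 2-chlorophenyl and 4-chlorophenyl compounds. Chloro in place of trifluoromethyl on an aromatic carbon gives a 2.1-fold higher number from compound 1 to compound 3 (0.32 log units; beyond the scatter) as a step beyond the scatter, so the change of substituent now stands apart from the change of its place, which were combined in the earlier step. Nothing at hand accounts for either step.
The compounds shown leave open how a methoxy group, a nitrile or an amine in place of the chlorine would read.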